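The source may report more compounds than this note shows. Statements on the series, on what has been measured and on what is new or still open speak of the compounds shown alone.

Compound 1 `O=C1C(Nc2ccc(Br)cc2)=CC(=O)c2c1nc1n2[C@H]2OC[C@@H](O)[C@H]2OC1`, compound 2 `COc1ccccc1NC1=CC(=O)c2c(nc3n2[C@H]2OC[C@@H](O)[C@H]2OC3)C1=O` and compound 3 `COc1ccc(NC2=CC(=O)c3c(nc4n3[C@H]3OC[C@@H](O)[C@H]3OC4)C2=O)cc1` share a core and differ only in the aromatic group on an amine nitrogen. In a functional assay on MCF7 cells (Homo sapiens) for inhibition, read by sulforhodamine B assay (on this read-out lower numbers stand for stronger inhibition and higher numbers for weaker inhibition), compound 1 gives 4330 nM, compound 2 gives 6580 nM and compound 3 gives 4470 nM. Compound 3 is not separated from either neighbour: the measured steps are a 1.0-fold higher number from compound 1 to compound 3 (0.01 log units; within the scatter) and a 1.5-fold lower number from compound 2 to compound 3 (0.17 log units; within the scatter), and the remaining one is a 1.5-fold higher number from compound 1 to compound 2 (0.18 log units; within the scatter). The three values therefore form a single flat group.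

Compound 4 `O=C1C(NC2CC2)=CC(=O)c2c1nc1n2[C@H]2OC[C@@H](O)[C@H]2OC1` brings a larger change: cyclopropyl in place of 4-methoxyphenyl on an amine nitrogen. In words, this is cyclopropyl in place of 4-methoxyphenyl on an amine nitrogen, or (4-methoxyphenyl)amino to cyclopropylamino. The measured steps bear on it only indirectly, since each swaps one aromatic group for another and none removes the aromatic ring. They show that this assay tolerated those swaps, with a 1.0-fold higher number from compound 1 to compound 3 (0.01 log units; within the scatter) as the smallest and a 1.5-fold higher number from compound 1 to compound 2 (0.18 log units; within the scatter) as the largest. No step beyond the scatter is therefore expected, and the data give no firm direction, so the range is kept wide. The expected step is a 1.2-fold higher number from compound 3 to compound 4 (0.09 log units; within the scatter). The estimate for compound 4 is 5500 nM, with an expected range of 2200 nM to 13000 nM.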

Compound 4, half-maximal inhibitory concentration: > 16000 nM
Compound 4: only a limit was reported; the forecaster's own chance of this, stated with the estimate: 8%; middle value at least 2.9-fold (0.46 log units) from the limit.
By their numbers in this assay, from the lowest: compounds 1, 3 and 2 (each within the scatter of the next). At a limit, above all of these: compound 4.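

Working notes on the group on the amine nitrogen: this position is not indifferent to every change, as the aromatic swaps alone suggested. In this assay the 4-bromophenyl, 2-methoxyphenyl and 4-methoxyphenyl compounds stay within the scatter of one another, whereas cyclopropyl separates from all three towards weaker inhibition, with an at least 3.5-fold higher number from compound 3 to compound 4 (0.55 log units; beyond the scatter), an at least 2.4-fold higher number from compound 2 to compound 4 (0.38 log units; beyond the scatter) and an at least 3.6-fold higher number from compound 1 to compound 4 (0.56 log units; beyond the scatter). Compound 4 is recorded only as a limit and not as a number, so these steps are floors and their full size stays unknown: the limit of > 16000 nM in this assay, at which 1 of the 4 values shown sits.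

On these data alone, it remains open whether the shift follows the loss of the aromatic ring or the change in the size of the group, and a cyclohexyl group, a benzyl group or a longer alkyl chain on the same nitrogen would help to separate these two readings. As far as these compounds go, it is also open how far the flat behaviour of the aryl compounds extends, for instance to a phenyl ring carrying a carboxylic acid or a dimethylamino group.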